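The compounds below may be only part of what the source reports. "The series", "measured", "known", "first", "only" and "open" are said of these compounds alone.

Values in a functional assay on CAPAN-1 cells (Homo sapiens) for antiproliferative activity, with a stated time of 72 h; a higher number here means a weaker inhibitor, a lower number a stronger inhibitor:
compound 1 `CC(C)(CO)Cn1nc(-c2c[nH]c3ccccc23)c2c(N)ncnc21`: 4700 nM
compound 2 `Cn1cc(-c2nn(C(C)(C)C)c3ncnc(N)c23)c2ccccc21`: 21300 nM
compound 3 `Nc1ncnc2c1c(-c1c[nH]c3ccccc13)nn2CC1CCNCC1`: 40700 nM

Compound 3, at 40700 nM, lies within the scatter of compound 2, at 21300 nM. Both numbers are higher than that of compound 1, at 4700 nM.

Next in the series is compound 4 `CC(C)(C)n1nc(-c2c[nH]c3ccccc23)c2c(N)ncnc21`, not yet measured. It has tert-butyl in place of (piperidin-4-yl)methyl on an aromatic nitrogen.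

Going by the values given here, only one measured step bears on this change: an 8.7-fold higher number from compound 1 to compound 3 (0.94 log units; beyond the scatter). That step is beyond the scatter, and it introduces the piperidin-4-yl group while the number rises. Compound 4 removes this ring, so the working expectation in this assay is a move the opposite way, towards a lower number. The evidence is thin, however, since a single step supports it and tert-butyl is not the group carried by compound 1. The expected move is therefore somewhat smaller than the measured step, and the range is kept wide.

The estimated change is a 4.1-fold lower number from compound 3 to compound 4 (0.61 log units; beyond the scatter).

For compound 4 the expected value is 10000 nM, with an estimated range of 3000 nM to 32000 nM.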

Compound 4, half-maximal inhibitory concentration: 1600 nM
Compound 4: middle estimate off by 6.3-fold (0.80 log units), on the high side; the whole stated range lies above it.
By their numbers in this assay, from the lowest: compound 4; then compound 1; then compounds 2 and 3 (each within the scatter of the next).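

In this assay, going by these compounds alone, the group on the aromatic nitrogen of the five-membered ring has more influence than the earlier compounds could show: tert-butyl, with no ring and no hydrogen-bond donor or acceptor, gives a 25-fold lower number from compound 3 to compound 4 (1.41 log units; beyond the scatter) against (piperidin-4-yl)methyl, and it also outperforms the open chain, with a 2.9-fold lower number from compound 1 to compound 4 (0.47 log units; beyond the scatter) against 2-(hydroxymethyl)-2-methylpropyl. With tert-butyl held in place, the other aromatic nitrogen also matters, since hydrogen in place of methyl gives a 13-fold lower number from compound 2 to compound 4 (1.12 log units; beyond the scatter), so compound 4, at 1600 nM, is the strongest of the four, its steps to all the others lying beyond the scatter. Nothing at hand accounts for these steps in terms of any measured property of the groups.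

Still open, from the compounds shown here alone, is whether the low number depends on tert-butyl itself or would also hold with isopropyl, cyclopentyl or a short chain ending in an amine on the same nitrogen. Going by these compounds, it is equally open whether any group on the other aromatic nitrogen, such as ethyl or a chain ending in a carboxylic acid, could be tolerated alongside tert-butyl.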